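This account rests on a few compounds, and the source may have more. Where it says the series, first, only, none or still open, it means among the compounds named here.

Three hydroxamic acids built on one shared core have been measured in a functional assay on NCI-H23 cells (Homo sapiens) for inhibition, read by sulforhodamine B assay; on this read-out higher numbers stand for weaker inhibition of growth and lower numbers for stronger inhibition of growth. Compound 1 `Cc1cccc(CN2CC=C(CCC(=O)NO)C2=O)c1` gives 2500 nM there, and compound 2 `Cc1ccc(CN2CC=C(CCC(=O)NO)C2=O)cc1` gives 2500 nM in this assay, the same number at the digits recorded and well within the scatter of each other, so no order between them can be claimed. Compound 3 `O=C(CCC1=CCN(CCCCc2ccc(Cl)cc2)C1=O)NO` gives 6250 nM in this assay, a number beyond the scatter above compound 1. Compound 1 thus stands together with compound 2 at the lowest level of the three, with compound 3 its furthest neighbour.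

The step from compound 1 leads to compound 4 `N#Cc1cccc(CN2CC=C(CCC(=O)NO)C2=O)c1`, which has not yet been measured. The change is cyano in place of methyl on an aromatic carbon. Going by the values given here, no pair of measured compounds differs in this place alone, so nothing among the measured compounds gives the size of such a step directly. Compound 1 and compound 2 both carry a methyl on the ring and give the same number, which gives no sign that a small change in that group shifts the read-out much. The step from compound 1 to compound 4 is therefore expected to be a 1.2-fold higher number from compound 1 to compound 4 (0.08 log units; within the scatter) in this assay, none beyond the scatter. Compound 4 is estimated at 3000 nM in this assay, with a range from 1200 nM to 8000 nM.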

Compound 4, concentration for 50% growth inhibition: 4080 nM
For compound 4 the middle estimate is 1.4-fold (0.13 log units) below the measured one; low and high end bracket the measured number.
By their numbers in this assay, from the lowest: compounds 1, 2, 4 and 3 (each within the scatter of the next, the first and the last beyond it).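

Going by these compounds alone, compound 4 gives the first measured step at this position, with cyano in place of methyl on an aromatic carbon, meta to a large group. In this assay that step is a 1.6-fold higher number from compound 1 to compound 4 (0.21 log units; within the scatter), so this exchange of methyl for cyano, which adds a hydrogen-bond acceptor and a triple bond, does not separate the two compounds on this read-out. Nothing available bears on why the step has this size.

The compounds shown leave open how an amine, a carboxylic acid or a methoxy group would read on this same aromatic carbon. They also leave open whether cyano in place of methyl on the ring of compound 2, where the methyl stands at a different ring position, would give a step of similar size.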